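This account rests on a few compounds, and the source may have more. Where it says the series, first, only, none or still open, it means among the compounds named here.

Measured compounds in a functional assay on QGY7701 cells (Homo sapiens) for cytotoxicity, read by MTT assay, with a stated time of 48 h; a lower number here means a stronger inhibitor, a higher number a weaker inhibitor:
- compound 1 `Cc1ccccc1Cn1cc(COc2ccc3c(=O)ccoc3c2)nn1`; here compound 1 gives > 100000 nM, which is a limit of the assay, not a number.
- compound 2 `O=c1ccoc2cc(OCc3cn(Cc4ccc(Br)cc4)nn3)ccc12`; compound 2 gives 96400 nM.
- compound 3 `O=c1ccoc2cc(OCc3cn(Cc4ccccc4F)nn3)ccc12`; compound 3 gives 36900 nM.

Compound 1 stands at the limit of this assay, so only a bound is known for it (the limit of > 100000 nM in this assay, at which 1 of the 3 values shown sits). The step to compound 4 `COc1ccc(Cn2cc(COc3ccc4c(=O)ccoc4c3)nn2)cc1` is 4-methoxyphenyl in place of 2-methylphenyl on a saturated chain carbon bound to an aromatic nitrogen. Two measured steps start from compound 1 and change the same part of the molecule: an at least 1.0-fold lower number from compound 1 to compound 2 (0.01 log units; that floor lies within the scatter), and an at least 2.7-fold lower number from compound 1 to compound 3 (0.43 log units; beyond the scatter). Between the two measured substituted compounds, a 2.6-fold lower number from compound 2 to compound 3 (0.42 log units; beyond the scatter). A change on the same phenyl ring of a different kind therefore has moved the number at most modestly, and the one other 4-substituted phenyl, in compound 2, sits within scatter of the limit of compound 1. Compound 4 is thus expected to stay in the weak range, with a step of about an at least 1.2-fold lower number from compound 1 to compound 4 (0.09 log units; that floor lies within the scatter), and to give roughly 80000 nM, in the range 30000 nM to 250000 nM, with a fair chance that this assay again reports only a limit.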

Compound 4, half-maximal inhibitory concentration: 56600 nM
Compound 4: the middle estimate sits 1.4-fold (0.15 log units) above what was measured; the measured number falls inside the stated range.
By their numbers in this assay, from the lowest: compounds 3, 4 and 2 (each within the scatter of the next, the first and the last beyond it). At a limit, above all of these: compound 1.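

In this assay, 4-methoxyphenyl on a saturated chain carbon bound to an aromatic nitrogen gives a measured value, and the change from 2-methylphenyl reads as an at least 1.7-fold lower number from compound 1 to compound 4 (0.24 log units; that floor lies within the scatter). Methoxy in place of bromo on an aromatic carbon gives a 1.7-fold lower number from compound 2 to compound 4 (0.23 log units; within the scatter), and 4-methoxyphenyl in place of 2-fluorophenyl gives a 1.5-fold higher number from compound 3 to compound 4 (0.19 log units; within the scatter), so compound 4 separates from neither compound 2 nor compound 3, although those two stand apart beyond the scatter. Compound 1 remains at a limit of the assay: the limit of > 100000 nM in this assay, at which 1 of the 4 values shown sits.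

In the compounds shown, the identity of the group and its place on the phenyl ring change together, so the two effects stay unseparated. Going by these compounds, whether an amine or a carboxylic acid on the phenyl ring, or a longer chain in place of the benzyl link, would move the number also remains open.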